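The source may hold more compounds than are shown below. What is called first, only, known or untested is meant among the compounds shown, and "the series" means these compounds.

Compound 1 `O=C(O)COc1ccncc1-c1ccc2ccccc2c1` gave "not determined" (no result reported) in an assay on a protein complex for inhibition of CDK8/Cyclin C (Homo sapiens), with a stated time of 1 h; on this read-out higher numbers stand for weaker inhibition and lower numbers for stronger inhibition. Among the compounds with values here, compound 2 `CNC(=O)CCc1ccncc1-c1ccc2ccccc2c1` is the only compound with a number here: in this assay compound 2 gives 21.1 nM. Compound 3 `COC(=O)/C=C/c1ccncc1-c1ccc2ccccc2c1` carries 2-(methoxycarbonyl)ethenyl in place of 2-(methylcarbamoyl)ethyl on an aromatic carbon. Within the data shown here, no step between two measured compounds is known, so the weight of this change can only be estimated from the structures themselves. The expected step of a 2.4-fold higher number from compound 2 to compound 3 (0.37 log units; beyond the scatter) points to somewhat weaker inhibition, a little beyond the scatter. For compound 3 the estimate in this assay is 50 nM, within a range from 15 nM to 200 nM.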

Compound 3, half-maximal inhibitory concentration: 40.6 nM
The estimate for compound 3 lay 1.2-fold (0.09 log units) above the measured number; the range from low to high includes it.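

In this assay, placing 2-(methoxycarbonyl)ethenyl in place of 2-(methylcarbamoyl)ethyl on this aromatic carbon gives a 1.9-fold higher number from compound 2 to compound 3 (0.28 log units; within the scatter), so the two compounds cannot be told apart. This position thus accepts a swap that removes the hydrogen-bond donor and adds a double bond outside the aromatic rings, with no change beyond the scatter. Nothing available here explains this result. From the compounds shown here alone, the swap alters the chain and its end group together, so their separate contributions remain open. Going by these compounds, how a carboxylic acid, an amine or a longer chain would fare here also remains open.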